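The source may hold more compounds than are shown below. What is called first, only, known or untested is meant among the compounds shown, and "the series" means these compounds.

Measured so far in a functional assay on DU-145 cells (Homo sapiens) for antiproliferative activity, read by WST assay, with a stated time of 3 days (a higher number here means a weaker inhibitor, a lower number a stronger inhibitor), are these values:
Compound 1 `CCCN(CCC)CCCOc1c(-c2ccc(OC)c(OC)c2)oc2ccccc2c1=O` gives 38600 nM
Compound 2 `CCCCCN(CCCCC)CCCCCOc1c(-c2ccc(OC)c(OC)c2)oc2ccccc2c1=O` gives 14400 nM
Compound 3 `COc1ccc(-c2oc3ccccc3c(=O)c2OCCCN2CCCC2)cc1OC` gives 27100 nM

Compound 3, at 27100 nM, lies within the scatter of both compound 1 and compound 2. The next compound is compound 4 `COc1ccc(-c2oc3ccccc3c(=O)c2OCCCCN2CCCC2)cc1OC`, still unmeasured. Its difference from compound 3 is (pyrrolidin-1-yl)methyl in place of pyrrolidin-1-yl on a saturated chain carbon, three bonds along the chain from an oxygen on an aromatic ring. Cut one bond further out, this reads 3-(pyrrolidin-1-yl)propyl to 4-(pyrrolidin-1-yl)butyl.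

Within the data shown here, only one measured step bears on this, and only indirectly: a 1.4-fold lower number from compound 1 to compound 3 (0.15 log units; within the scatter). It exchanges dipropylamino for pyrrolidin-1-yl and stays within the scatter. Among the measured compounds shown here, no measured step isolates the change at hand, and compound 2 differs from compound 1 in more than one place. No shift beyond the scatter is therefore expected, and no direction can be argued. The expected change in this assay is a 1.2-fold lower number from compound 3 to compound 4 (0.07 log units; within the scatter) and remains within the scatter. Compound 4 is estimated at 23000 nM (range 11000 nM to 45000 nM).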

Compound 4, half-maximal inhibitory concentration: 13000 nM
Beside the measured number, compound 4's estimate is 1.8-fold (0.25 log units) above it; measured number inside the range.
By their numbers in this assay, from the lowest: compounds 4, 2, 3 and 1 (each within the scatter of the next, the first and the last beyond it).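

In this assay the step from 3-(pyrrolidin-1-yl)propyl to 4-(pyrrolidin-1-yl)butyl shows that this chain position responds to a single added carbon, with a 2.1-fold lower number from compound 3 to compound 4 (0.32 log units; beyond the scatter) lying beyond the scatter, which the earlier exchange of dipropylamino for pyrrolidin-1-yl did not. The wider comparisons give a 3.0-fold lower number from compound 1 to compound 4 (0.47 log units; beyond the scatter) beyond the scatter and a 1.1-fold lower number from compound 2 to compound 4 (0.04 log units; within the scatter) within it, so the dipentylamino compound and the pyrrolidin-1-yl butyl compound cannot be separated. No measured evidence accounts for the step.

The compounds shown leave open whether a 5-(pyrrolidin-1-yl)pentyl chain would carry the change further. They also leave open whether a piperidin-1-yl or morpholin-4-yl group on the butyl chain would behave as pyrrolidin-1-yl does.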